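The source may report more compounds than this note shows. Statements on the series, on what has been measured and on what is new or still open speak of the compounds shown alone.

In a functional assay on HepG2 cells (Homo sapiens) for antiproliferative activity, read by XTT assay, with a stated time of 72 h (a higher number here means a weaker inhibitor, a lower number a stronger inhibitor), compound 1 `CNc1ncnc2c1c(-c1ccco1)cn2[C@@H]1O[C@H](CO)[C@@H](O)[C@H]1O` gives 850 nM. Compound 2 `CNc1ncnc2c1c(-c1ccccc1)cn2[C@@H]1O[C@H](CO)[C@@H](O)[C@H]1O` gives only a limit, > 20000 nM. Compound 3 `CNc1ncnc2c1c(-c1cc3ccccc3o1)cn2[C@@H]1O[C@H](CO)[C@@H](O)[C@H]1O` has 1-benzofuran-2-yl in place of phenyl on an aromatic carbon. For the measured compounds named here, one measured step bears on this change: an at least 23-fold higher number from compound 1 to compound 2 (1.37 log units; beyond the scatter), a large rise with phenyl in place of furan-2-yl. Compound 3 keeps a furan ring within its benzofuran, so part of that loss is expected to return, though the added benzene ring leaves the size uncertain. A moderate fall in this assay is expected, an estimated at least 3.3-fold lower number from compound 2 to compound 3 (0.52 log units; beyond the scatter). For compound 3 the estimate is 6000 nM, with an expected range of 1200 nM to 20000 nM.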

Compound 3, half-maximal inhibitory concentration: > 20000 nM
Compound 3 ended at the assay's limit (the forecaster's own chance of this, stated with the estimate: 35%); at least 3.3-fold (0.52 log units) between middle value and limit.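

In this assay, 1-benzofuran-2-yl in place of furan-2-yl on this aromatic carbon gives an at least 23-fold higher number from compound 1 to compound 3 (1.37 log units; beyond the scatter). A furan ring held within the larger fused group therefore does not preserve the activity of compound 1, which remains the only compound shown with a readable value. The step between compound 2 and compound 3 cannot be read because both values are limits: the limit of > 20000 nM in this assay, at which 2 of the 3 values shown sit.

Going by these compounds, it remains open how far compound 2 and compound 3 differ beyond the limit. On these data alone, it is also open whether a thiophen-2-yl or methyl group on this carbon would retain measurable activity.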